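Replacing the amide substituent of compound 3

The compounds below may be only part of what the source reports. "The series", "measured", "known", "first", "only" and "open" are said of these compounds alone.

For compound 1 `Cc1noc(C)c1-c1nn(Cc2ccc(C(=O)NC3CC3)cc2)c(=O)c2ccccc12` the reading in a functional assay on A549 cells (Homo sapiens) for antiproliferative activity, read by MTT assay, with a stated time of 72 h (a higher number here means a weaker inhibitor, a lower number a stronger inhibitor), is > 100000 nM as a limit of the assay and not a number. Compound 2 `Cc1noc(C)c1-c1nn(Cc2ccc(C(=O)N3CCCCC3)cc2)c(=O)c2ccccc12` measures 86200 nM and compound 3 `Cc1noc(C)c1-c1nn(Cc2ccc(C(=O)NC3CC(C)(C)N([O])C(C)(C)C3)cc2)c(=O)c2ccccc12` measures 84300 nM in this assay, so these two stand within the scatter of each other.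

Compound 4 `Cc1noc(C)c1-c1nn(Cc2ccc(C(=O)NC3CCN(C)CC3)cc2)c(=O)c2ccccc12` has not yet been measured. On the amide-type nitrogen it carries 1-methylpiperidin-4-yl in place of the group in compound 3 (a group of 7 heavy atoms (6 carbon, 1 nitrogen; one six-membered non-aromatic ring with 1 hetero atom) in place of a group of 11 heavy atoms (9 carbon, 1 nitrogen, 1 oxygen; one six-membered non-aromatic ring with 1 hetero atom), on an amide-type nitrogen).

Exchanging the group on that nitrogen gave an at least 1.1-fold lower number from compound 1 to compound 3 (0.07 log units; that floor lies within the scatter) and changes on the carbonyl carbon gave an at least 1.1-fold lower number from compound 1 to compound 2 (0.06 log units; that floor lies within the scatter) and a 1.0-fold lower number from compound 2 to compound 3 (0.01 log units; within the scatter), each of them, or its floor, within the scatter. No step beyond the scatter is therefore expected here. The expected change is a 1.1-fold higher number from compound 3 to compound 4 (0.03 log units; within the scatter) in this assay, which would stay within the scatter. For compound 4 the estimated value is 90000 nM with an expected range of 45000 nM to 150000 nM in this assay, and a reading reported only as a limit remains possible.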

Compound 4, half-maximal inhibitory concentration: > 100000 nM
Compound 4: only a limit was reported; the forecaster's own chance of this, stated with the estimate: 35%; middle value at least 1.1-fold (0.04 log units) from the limit.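

In this assay compound 4 gives a limit of the assay and not a number, and it is the second compound with a group on the amide-type nitrogen to do so: the limit of > 100000 nM in this assay, at which 2 of the 4 values shown sit. The change of group gives an at least 1.1-fold higher number from compound 3 to compound 4 (0.07 log units; that floor lies within the scatter), and the exchange on the carbonyl carbon gives an at least 1.1-fold higher number from compound 2 to compound 4 (0.06 log units; that floor lies within the scatter), so neither step separates 1-methylpiperidin-4-yl from the group it is compared with, while the step from compound 1 to compound 4 cannot be read, as both are limits. Among the four compounds shown, no group at this place has yet produced a step beyond the scatter.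

On these data alone, how far the true value of compound 4 lies from its limit remains open. Also open, as far as these compounds go, is whether an open-chain amine, a carboxylic acid or a longer chain on the amide-type nitrogen would give a step beyond the scatter.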